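Diethoxy chain for hydroxy chain: estimating compound 4

The compounds below may be only part of what the source reports. "The series", "measured", "known", "first", "only" and "open" are said of these compounds alone.

Measured so far in an ADME assay on MDA-MB-231 cells (Homo sapiens) for inhibition, read by MTT assay, with a stated time of 24 h (on this read-out lower numbers stand for stronger inhibition and higher numbers for weaker inhibition), with every entry a limit of the assay and not a number:
- compound 1 `CC(C)=CCC[C@H](C)c1ccc(C)c2c1OCN(CC1CCNCC1)C2` gives > 20000 nM as a limit
- compound 2 `CC(C)=CCC[C@H](C)c1ccc(C)c2c1OCN(CCCCCO)C2` gives > 20000 nM as a limit
- compound 3 `CC(C)=CCC[C@H](C)c1ccc(C)c(CNCCCCC(=O)O)c1O` gives > 20000 nM as a limit

Compound 2 stands at a limit, > 20000 nM and no exact number. All the data so far come down to the limit of > 20000 nM in this assay, at which 3 of the 3 values shown sit, and no ranking of the three compounds can be drawn from that.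

In compound 4 `CCOC(CCN1COc2c([C@@H](C)CCC=C(C)C)ccc(C)c2C1)OCC` diethoxymethyl takes the place of 3-hydroxypropyl on a saturated chain carbon, two bonds along the chain from an amine nitrogen in a ring diethoxymethyl in place of 3-hydroxypropyl on a saturated chain carbon, two bonds along the chain from an amine nitrogen in a ring and the rest of the structure stays the same.

Within the data shown here, the only measured step that bears on this is a step that the two limits leave unreadable from compound 1 to compound 2 and it offers no size to carry over. No shift in either direction can therefore be expected beyond the scatter, and another limit is the likeliest result in this assay for this compound. The expected step is a step that the limit leaves unreadable from compound 2 to compound 4 and it rests on the limit of > 20000 nM in this assay, at which 3 of the 3 values shown sit, alone. For compound 4 the estimated value is 25000 nM with an expected range of 10000 nM to 50000 nM overall.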

Compound 4, half-maximal inhibitory concentration: > 20000 nM
Compound 4: only a limit was reported; the forecaster's own chance of this, stated with the estimate: 75%; the middle value lies beyond the limit too.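

Compound 4 gives > 20000 nM, a limit and not a number. No step between compound 4 and compound 1 or compound 2 can be read, as all the results end at the same limit: the limit of > 20000 nM in this assay, at which 4 of the 4 values shown sit.

The compounds shown leave open how strongly any of them inhibits, and whether changing the chain on the shared core alters that at all.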